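Toward compound 3: methoxy in place of methyl

A few compounds are considered here, and "the series" means these few. Any claim that something is new, unique, unknown or untested is made for them only; others in the source may bear on it.

Measured so far:
compound 1 `Cc1ncnc2c1c(I)cn2[C@@H]1O[C@H](CO)[C@@H](O)[C@H]1O` — > 100000 nM
compound 2 `Cc1ncnc2c1c(-c1cccs1)cn2[C@@H]1O[C@H](CO)[C@@H](O)[C@H]1O` — > 100000 nM

In an ADME assay on BJ cells (Homo sapiens), read by MTT assay, with a stated time of 72 h (a lower number here means a stronger inhibitor, a higher number a weaker inhibitor), compound 1 gives only a limit, > 100000 nM. In this assay compound 2 likewise gives only a limit, > 100000 nM. Among the compounds with values here, the one measured step, a step that the two limits leave unreadable from compound 1 to compound 2, therefore cannot be sized, because of the limit of > 100000 nM in this assay, at which 2 of the 2 values shown sit. Compound 1 thus stands at that limit with no numerical value of its own.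

Compound 3 `COc1ncnc2c1c(I)cn2[C@@H]1O[C@H](CO)[C@@H](O)[C@H]1O` is not yet measured in this assay. It differs from compound 1 as follows: methoxy in place of methyl on an aromatic carbon. Within the data shown here, no measured step covers a change of this kind, so the expectation rests on the two limits alone.

Compound 3 is expected to give 100000 nM in this assay, most likely again only as a limit, within 30000 nM to 300000 nM. The expected step of a number no higher from compound 1 to compound 3 (the limit leaves the size open) is thus none beyond the scatter.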

Compound 3, half-maximal inhibitory concentration: 91000 nM
The estimate for compound 3 lay 1.1-fold (0.04 log units) above the measured number, within the range that was stated.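

In this assay, within the data shown here, compound 3 gives 91000 nM, the first number that is not a limit. Methoxy in place of methyl on an aromatic carbon, with the iodo group kept, gives an at least 1.0-fold lower number from compound 1 to compound 3 (0.04 log units; that floor lies within the scatter), so the change is not shown to move the read-out beyond the scatter, although its true size stays open. The step with limits at both ends, the thiophen-2-yl change, cannot be read: the limit of > 100000 nM in this assay, at which 2 of the 3 values shown sit.

Still open, as far as these compounds go, is whether an amine or an ethoxy group at this same place would give a number clearly apart from that of compound 3. Also open, from the compounds shown here alone, is what methoxy gives when thiophen-2-yl stands in place of iodo on the shared core.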